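The compounds below may be only part of what the source reports. "The series", "measured", "known", "first", "only" and "open" are said of these compounds alone.

Measured in a functional assay on DU-145 cells (Homo sapiens) for cytotoxicity, read by MTT assay, with a stated time of 48 h; a lower number here means a stronger inhibitor, a higher number a weaker inhibitor:
- compound 1 `COc1cc(-c2cc(COCc3cn(Cc4cc(-c5ccccc5)cnc4Cl)nn3)on2)cc(OC)c1OC`: 78500 nM
- compound 2 `COc1cc(-c2cc(COCc3cn(Cc4cc(C)cnc4Cl)nn3)on2)cc(OC)c1OC`: 39800 nM

These two numbers lie within the scatter of each other, so compound 2 holds no clear rank in this small set. The next compound is compound 3 `COc1cc(-c2cc(COCc3cn(Cc4cc(-c5ccc(F)cc5)cnc4Cl)nn3)on2)cc(OC)c1OC`, and the change is 4-fluorophenyl in place of methyl on an aromatic carbon. Going by the values given here, one measured step bears on this change: a 2.0-fold lower number from compound 1 to compound 2 (0.29 log units; within the scatter), with methyl in place of phenyl on an aromatic carbon. Among the compounds with values here, that step stays within the scatter, and no measured compound yet carries 4-fluorophenyl. A large aromatic group on this carbon is therefore not expected to move the number beyond the scatter in this assay, with any drift expected towards a higher number. The estimated step is a 1.5-fold higher number from compound 2 to compound 3 (0.18 log units; within the scatter). Compound 3 is expected at 60000 nM, with an estimated range of 25000 nM to 140000 nM.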

Compound 3, half-maximal inhibitory concentration: 31900 nM
Beside the measured number, compound 3's estimate is 1.9-fold (0.27 log units) above it; the range from low to high includes it.
By their numbers in this assay, from the lowest: compounds 3, 2 and 1 (each within the scatter of the next, the first and the last beyond it).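

In this assay, a large aromatic group on this carbon of the ring with one nitrogen gives a 1.2-fold lower number from compound 2 to compound 3 (0.10 log units; within the scatter), so 4-fluorophenyl and methyl cannot be told apart here. Going by these compounds alone, the one step beyond the scatter lies on the phenyl ring itself: fluoro in place of hydrogen gives a 2.5-fold lower number from compound 1 to compound 3 (0.39 log units; beyond the scatter), a modest step that rests on this single pair. Nothing available accounts for either step.

As far as these compounds go, whether the fluoro step is specific to fluorine stays open, as a chloro or methoxy group in its place on the phenyl ring would be needed to test it. Also open, from the compounds shown here alone, is whether an amine or a carboxylic acid on the carbon that carries methyl in compound 2 would move the number beyond the scatter.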